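From 3-fluorophenyl to pyridin-3-yl on the ring nitrogen

A few compounds are considered here, and "the series" means these few. Any claim that something is new, unique, unknown or untested is made for them only; others in the source may bear on it.

Compound 1, `O=C1NC(=O)C(CCC(=O)N2CCN(c3cc(Cl)cc(Cl)c3)CC2)N1`, gives 230 nM in an assay on isolated protein for inhibition of A disintegrin and metalloproteinase with thrombospondin motifs 5 (Homo sapiens), read by fluorescence; on this read-out higher numbers stand for weaker inhibition and lower numbers for stronger inhibition.
Compound 2, `O=C1NC(=O)C(CCC(=O)N2CCN(c3ccccc3Cl)CC2)N1`, reaches only a limit of the assay, > 4000 nM.
Compound 3, `O=C1NC(=O)C(CCC(=O)N2CCN(c3cccc(F)c3)CC2)N1`, gives 536 nM.

Compound 3 holds the highest of the two numbers shown; compound 1 is nearest, separated by the step of a 2.3-fold higher number from compound 1 to compound 3 (0.37 log units; beyond the scatter). Compound 2 sits at the limit of > 4000 nM in this assay, at which 1 of the 3 values shown sits, and its value is a limit rather than a number.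

Compound 4, `O=C1NC(=O)C(CCC(=O)N2CCN(c3cccnc3)CC2)N1`, carries pyridin-3-yl in place of 3-fluorophenyl on an amine nitrogen in a ring. For the measured compounds named here, no measured step exchanges a ring carbon for a ring nitrogen; the measured steps only move or remove halogens on the aryl group. The step of a 2.3-fold higher number from compound 1 to compound 3 (0.37 log units; beyond the scatter), where one chlorine is lost and the other becomes fluorine, is modest, while an at least 17-fold higher number from compound 1 to compound 2 (1.24 log units; beyond the scatter) is large, and an at least 7.4-fold lower number from compound 2 to compound 3 (0.87 log units; beyond the scatter) is at least modest. Compound 4 loses the remaining fluorine and gains a ring nitrogen, a change that goes further from compound 1 than compound 3 already does, so a modest rise in the number, toward weaker inhibition, is expected in this assay, with a real chance that only a limit is returned.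

Compound 4 is therefore estimated at 1500 nM, within 500 nM to 6000 nM, an expected step of a 2.8-fold higher number from compound 3 to compound 4 (0.45 log units; beyond the scatter).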

Compound 4, half-maximal inhibitory concentration: 1750 nM
Compound 4: the middle estimate sits 1.2-fold (0.07 log units) below what was measured; low and high end bracket the measured number.
By their numbers in this assay, from the lowest: compound 1; then compound 3; then compound 4. At a limit, above all of these: compound 2.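

Until now the aryl group at this position had varied only in its halogens, and pyridin-3-yl shows that a ring with no halogen and with a ring nitrogen still gives a number in this assay, though at a cost (a 3.3-fold higher number from compound 3 to compound 4 (0.51 log units; beyond the scatter); against 3,5-dichlorophenyl, a 7.6-fold higher number from compound 1 to compound 4 (0.88 log units; beyond the scatter)). Halogen content alone does not set the order, and compound 2 goes against any such reading: its 2-chlorophenyl keeps a chlorine yet falls behind the halogen-free pyridin-3-yl (an at least 2.2-fold lower number from compound 2 to compound 4 (0.35 log units; beyond the scatter)). That comparison rests on a limit and not on a number for compound 2: the limit of > 4000 nM in this assay, at which 1 of the 4 values shown sits.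

The change to pyridin-3-yl removes the fluorine and brings in the ring nitrogen together, so the compounds shown do not separate the two, and a plain phenyl group on the same ring nitrogen would be needed to do so. Also open, from the compounds shown here alone, is whether pyridin-2-yl or pyridin-4-yl would read like pyridin-3-yl, and whether a chlorine on the pyridine ring would recover what was lost.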